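Shifting the methoxy group on the benzyl of compound 3

This account rests on a few compounds, and the source may have more. Where it says the series, first, only, none or still open, it means among the compounds named here.

In a functional assay on K562 cells (Homo sapiens) for antiproliferative activity, read by MTT assay, with a stated time of 48 h (a higher number here means a weaker inhibitor, a lower number a stronger inhibitor), compound 1 `COc1ccc(-c2ccc3c(c2)C(=O)C(=O)N3)cc1` gives 6920 nM while compound 2 `COc1ccc(-c2ccc3c(c2)C(=O)C(=O)N3Cc2ccc(Br)cc2)cc1` gives 100 nM and compound 3 `COc1ccc(-c2ccc3c(c2)C(=O)C(=O)N3Cc2cccc(OC)c2)cc1` gives 680 nM and so stands between the other two. Compound 4 `COc1ccc(-c2ccc3c(c2)C(=O)C(=O)N3Cc2ccccc2OC)cc1` is not yet measured and differs from compound 3 in one place 2-methoxyphenyl in place of 3-methoxyphenyl on a saturated chain carbon bound to an amide-type nitrogen in a ring with 2-methoxyphenyl in place of 3-methoxyphenyl on a saturated chain carbon bound to an amide-type nitrogen in a ring. Replacing the hydrogen on that nitrogen gave large steps, a 69-fold lower number from compound 1 to compound 2 (1.84 log units; beyond the scatter) and a 10-fold lower number from compound 1 to compound 3 (1.01 log units; beyond the scatter) but compound 4 keeps a methoxybenzyl there. Among the compounds with values here, no measured step moves the methoxy group alone. The nearest guide is the modest 6.8-fold higher number from compound 2 to compound 3 (0.83 log units; beyond the scatter) which also exchanges the bromine for a methoxy group. A smaller step is therefore expected, probably none beyond the scatter and with no firm direction, and the estimate is a 1.2-fold higher number from compound 3 to compound 4 (0.07 log units; within the scatter) for now. In this assay compound 4 is estimated at 800 nM with an expected range of 250 nM to 2500 nM around that figure.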

Compound 4, half-maximal inhibitory concentration: 40 nM
Estimate against measurement, compound 4: 20-fold (1.30 log units) above, and the stated range ends above it.
By their numbers in this assay, from the lowest: compound 4; then compound 2; then compound 3; then compound 1.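

In this assay, within the data shown here, moving the methoxy group alone, with the same atoms joined differently, gives a 17-fold lower number from compound 3 to compound 4 (1.23 log units; beyond the scatter) and so counts as a large change at this place, one that no earlier step had isolated. The 2-methoxybenzyl group also gives a 2.5-fold lower number from compound 2 to compound 4 (0.40 log units; beyond the scatter) and a 170-fold lower number from compound 1 to compound 4 (2.24 log units; beyond the scatter) and leaves compound 4 with the lowest number of the four, so a methoxy group on this benzyl need not do worse than the bromine of compound 2, as compound 3 alone had suggested. Nothing available here accounts for the size of this shift. Going by these compounds, how a 4-methoxybenzyl, a 2-chlorobenzyl or a 2-aminobenzyl would compare with the 2-methoxybenzyl stays open. Also open, on these data alone, is whether the step from moving the methoxy group would hold with a hydroxyl in place of the methoxy group on the shared core.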